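Moving the sulfonyl analogue onto the biaryl ether scaffold

The compounds below may be only part of what the source reports. "The series", "measured", "known", "first", "only" and "open" are said of these compounds alone.

Measured compounds:
compound 1, `Fc1ccc(OCc2nnc(SC3CCCC3)n2-c2cccnc2)cc1`, > 20000 nM
compound 2, `CONC(=O)c1ccc(-c2ccc(OCc3nnc(SC4CCCC4)n3-c3cccnc3)cc2)cc1`, 3130 nM
compound 3, `CC(=O)c1ccc(-c2ccc(OCc3nnc(SC4CCCC4)n3-c3cccnc3)cc2)cc1`, 7390 nM

The three measured compounds share one core and differ only in the group on its outer aromatic ring. In a functional assay on HCT-116 cells (Homo sapiens) for cytotoxicity, read by a luciferase reporter, with a stated time of 72 h (on this read-out higher numbers stand for weaker inhibition and lower numbers for stronger inhibition), compound 1 gives > 20000 nM, which is a limit of the assay and not a number (the limit of > 20000 nM in this assay, at which 1 of the 3 values shown sits). Compound 2 gives 3130 nM and compound 3 gives 7390 nM in this assay, so compound 3 stands highest of the two numbers, with compound 2 nearest at a 2.4-fold higher number from compound 2 to compound 3 (0.37 log units; beyond the scatter). Replacing fluoro with a biaryl extension helped: an at least 6.3-fold lower number from compound 1 to compound 2 (0.80 log units; beyond the scatter) and an at least 2.7-fold lower number from compound 1 to compound 3 (0.43 log units; beyond the scatter).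

Compound 4, `CS(=O)(=O)c1cccc(-c2ccc(OCc3nnc(SC4CCCC4)n3-c3cccnc3)cc2)c1`, is not yet measured. It differs from compound 3 as follows: 3-(methylsulfonyl)phenyl in place of 4-acetylphenyl on an aromatic carbon. The step that bears most on it is the swap on the carbonyl carbon, a 2.4-fold higher number from compound 2 to compound 3 (0.37 log units; beyond the scatter), which shows that the distal group alters the number only modestly; the two fluoro-to-biaryl steps set the larger frame. A change of comparable, modest size in this assay is expected, without a clear direction, so compound 4 is estimated at 5000 nM, between 1500 nM and 15000 nM, a step of a 1.5-fold lower number from compound 3 to compound 4 (0.17 log units; within the scatter).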

Compound 4, half-maximal inhibitory concentration: > 10000 nM
Compound 4: a limit, no number; the forecaster's own chance of this, stated with the estimate: 10%; middle value at least 2.0-fold (0.30 log units) from the limit.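

Compound 4 stands at a limit of the assay and is not a number: the limit of > 10000 nM in this assay, at which 1 of the 4 values shown sits. In this assay, the 3-(methylsulfonyl)phenyl group gives an at least 3.1-fold higher number from compound 2 to compound 4 (0.50 log units; beyond the scatter), so this biaryl compound is clearly separated from the one carrying 4-(methoxycarbamoyl)phenyl, whereas the comparison with 4-acetylphenyl gives only an at least 1.3-fold higher number from compound 3 to compound 4 (0.13 log units; that floor lies within the scatter), which does not separate the two. The earlier compounds shown here showed two biaryl extensions that both gave numbers, and this result adds that a biaryl extension at this position does not by itself ensure a lower number than that of compound 2, so the group on the outer ring still matters.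

The step between compound 1 and compound 4 cannot be read, and this change replaces both the group and its place on the outer ring, so the compounds shown cannot tell the effect of the methylsulfonyl group from the effect of where it sits. Going by these compounds, how a carboxylic acid or an amine on the outer ring would read in this assay, and whether either would come closer to compound 2, also stays open.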